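This account rests on a few compounds, and the source may have more. Where it says the series, first, only, none or still open, it means among the compounds named here.

Compound 1 `O=C(CCCCC1CCSS1)Nc1ccccn1`: "not active" (no number reported)
Compound 2 `O=C(CCCCC(S)CCS)Nc1ccccc1`: 1.32%

In a functional assay on Bel-7402 cells (Homo sapiens) for inhibition, read by MTT assay, with a stated time of 24 h, tested at 1 ug/mL (a lower number here means less inhibition of growth, a higher number more inhibition of growth at the concentration tested), compound 2 gives 1.32%, the only numerical result so far. Compound 1 gives "not active" (no number reported), with no number reported. Compound 3 `O=C(CCCCC(S)CCS)Nc1ccccn1` differs from compound 2 by one change, pyridin-2-yl in place of phenyl on an amide-type nitrogen. Going by the values given here, no measured step between two compounds is available to size this change, so no shift beyond the scatter is expected, and no direction is favoured. The expected step is a number 1.7 percentage points higher from compound 2 to compound 3 (within the scatter). Compound 3 is estimated at 3%, with an expected range of 0% to 12%.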

Compound 3, percent growth inhibition at one concentration: "not active" (no number reported)
Compound 3: no number reported, and the estimate cannot be compared.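

Going by these compounds alone, compound 3 carries no number in this assay so no step from compound 2 to compound 3 can be read. Nothing available bears on this result. The compounds shown leave open how pyridin-2-yl in place of phenyl on an amide-type nitrogen shifts growth inhibition.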